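The source may hold more compounds than are shown below. What is called first, only, known or untested is meant among the compounds shown, and "the series" means these compounds.

For the measured compounds named here, compound 2 `Cn1c(C2CC2)nc2ccc(-n3ccc(OCc4ccccc4Cl)cc3=O)cc21` stands at the higher of the two numbers measured so far. Going by the values given here, in an assay on CHO cells for displacement of a labelled ligand from melanin-concentrating hormone receptor 1 (Homo sapiens), read by scintillation counting, with a stated time of 1 h (on this read-out lower numbers stand for stronger inhibition and higher numbers for weaker inhibition), compound 2 gives 160 nM, whereas compound 1 `Cn1c(C2CC2)nc2ccc(-n3ccc(OCc4cccc(Cl)c4)cc3=O)cc21` gives 100 nM; the only measured step, a 1.6-fold higher number from compound 1 to compound 2 (0.20 log units; within the scatter), therefore separates nothing that can be called a real difference. Compound 3 `Cn1c(C2CC2)nc2ccc(-n3ccc(OCc4ncc(Cl)cn4)cc3=O)cc21` is the next compound in this line, and its change from compound 2 is 5-chloropyrimidin-2-yl in place of 2-chlorophenyl on a saturated chain carbon bound to an oxygen on an aromatic ring. Among the compounds with values here, no measured step bears directly on this change: the one step in hand, a 1.6-fold higher number from compound 1 to compound 2 (0.20 log units; within the scatter), moves the chlorine around a carbon-only ring and stays within the scatter, while the step to compound 3 exchanges the ring itself for one carrying two hetero atoms, a kind of replacement for which no measurement in this set exists. With only that to lean on, the expectation for compound 3 is a step of modest size, a 2.0-fold higher number from compound 2 to compound 3 (0.30 log units; within the scatter), toward a higher number in this assay, with a wide spread allowed in either direction. On that basis compound 3 is estimated at 320 nM, with a range from 110 nM to 950 nM.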

Compound 3, half-maximal inhibitory concentration: > 1000 nM
Compound 3: only a limit was reported; the forecaster's own chance of this, stated with the estimate: 5%; middle value at least 3.1-fold (0.49 log units) away from the limit.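

In this assay, compound 3 is reported only as a limit: the limit of > 1000 nM in this assay, at which 1 of the 3 values shown sits. Even so, the change of ring on the saturated chain carbon bound to an oxygen on an aromatic ring can be sized, and it gives an at least 6.2-fold higher number from compound 2 to compound 3 (0.79 log units; beyond the scatter), while the comparison with the 3-chlorophenyl group gives an at least 10-fold higher number from compound 1 to compound 3 (1.00 log units; beyond the scatter). Where the earlier pair showed only a 1.6-fold higher number from compound 1 to compound 2 (0.20 log units; within the scatter), this position now shows a clear response to the ring itself: among these three compounds, the 2-chlorophenyl and 3-chlorophenyl groups stay close together and the 5-chloropyrimidin-2-yl group, with the same count of heavy atoms, lies well apart from both.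

The compounds shown leave open how far compound 3 lies past its limit, and whether the loss goes with the 2 ring nitrogens or with the changed place of the chlorine, as the single change alters both at once. A 4-chlorophenyl group, or a chloropyridinyl ring with one ring nitrogen, would bear on that question, and an unsubstituted pyrimidin-2-yl group would show what the chlorine contributes on this ring.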